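The source may hold more compounds than are shown below. What is called first, only, known or untested is meant among the compounds shown, and "the series" means these compounds.

Measured so far in a functional assay on MC-38 cells (Mus musculus) for antiproliferative activity, read by CCK-8 assay, with a stated time of 48 h; on this read-out higher numbers stand for weaker inhibition and lower numbers for stronger inhibition:
- compound 1 `COc1ccc(/C=C\c2cc(OC)c(OC)c(OC)c2)cc1OCc1ccc(CN2CCCC[C@H]2C(=O)O)cc1`: > 10000 nM
- compound 2 `COc1ccc(/C=C\c2cc(OC)c(OC)c(OC)c2)cc1OCc1ccc(CNCCO)cc1`: 1200 nM

The entry for compound 1 is > 10000 nM, and it is a limit of the assay, not a number. For the measured compounds named here, compound 2, at 1200 nM, therefore holds the only true number so far.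

Compound 3 `COc1ccc(/C=C\c2cc(OC)c(OC)c(OC)c2)cc1OCc1ccc(CO)cc1` carries hydroxy in place of (2-hydroxyethyl)amino on a saturated chain carbon bound to an aromatic carbon.

One measured step changes this same place: an at least 8.3-fold lower number from compound 1 to compound 2 (0.92 log units; beyond the scatter). It shows that changes here can move the read-out in this assay, but it involves a different group, and one end of it is a limit. It therefore offers only a loose guide. A further step towards a lower number, of modest size, seems the likeliest outcome, though no change beyond the scatter remains possible.

The estimated value for compound 3 is 300 nM, with an expected range of 40 nM to 2500 nM. This estimate means an expected 4.0-fold lower number from compound 2 to compound 3 (0.60 log units; beyond the scatter).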

Compound 3, half-maximal inhibitory concentration: 5700 nM
Compound 3: the middle estimate sits 19-fold (1.28 log units) below what was measured; measured number above the stated range.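

In this assay, replacing (2-hydroxyethyl)amino with hydroxy on a saturated chain carbon bound to an aromatic carbon gives a 4.8-fold higher number from compound 2 to compound 3 (0.68 log units; beyond the scatter), so the gain seen with compound 2 does not extend to every group that replaces 2-carboxypiperidin-1-yl, and compound 2 remains the strongest of the three. Hydroxy in place of 2-carboxypiperidin-1-yl gives an at least 1.7-fold lower number from compound 1 to compound 3 (0.24 log units; that floor lies within the scatter), so compound 3 cannot be clearly separated from compound 1. The entry for compound 1 is a limit of the assay, not a number: the limit of > 10000 nM in this assay, at which 1 of the 3 values shown sits.

From the compounds shown here alone, what stays open is whether the nitrogen or the hydroxyethyl end of compound 2 matters more. A plain amine, or a longer chain on that nitrogen, at this place would speak to that question.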